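Removing the ring methoxy: compound 3 to compound 4

This account rests on a few compounds, and the source may have more. Where it says the series, first, only, none or still open, it means among the compounds named here.

Among the compounds with values here, compound 3 `COc1ccc2[nH]c(-c3ccccc3)c(/C=C(\C#N)S(=O)(=O)c3ccccc3)c2c1` gives 3800 nM in a functional assay on NCI/ADR-RES cells (Homo sapiens) for inhibition, read by sulforhodamine B assay, with a stated time of 48 h (on this read-out higher numbers stand for weaker inhibition of growth and lower numbers for stronger inhibition of growth), the highest of the three numbers measured so far; compound 2 `CC(=O)/C(=C\c1c(-c2ccccc2)[nH]c2ccccc12)S(=O)(=O)c1ccccc1` at 520 nM and compound 1 `COc1ccc(-c2[nH]c3ccccc3c2/C=C(\C#N)S(=O)(=O)c2ccccc2)cc1` at 428 nM both sit beyond the scatter below it. Compound 4 `N#C/C(=C\c1c(-c2ccccc2)[nH]c2ccccc12)S(=O)(=O)c1ccccc1` is compound 3 with hydrogen in place of methoxy on an aromatic carbon. Within the data shown here, compounds 1 and 2 both carry hydrogen at that place and show the lower numbers, but each also differs from compound 3 elsewhere, so no single-change step is available in this assay. The expected step is a 5.4-fold lower number from compound 3 to compound 4 (0.73 log units; beyond the scatter), toward stronger growth inhibition and beyond the scatter. Compound 4 is therefore expected to give about 700 nM in this assay, within a range from 250 nM to 2500 nM.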

Compound 4, concentration for 50% growth inhibition: 1100 nM
Beside the measured number, compound 4's estimate is 1.6-fold (0.20 log units) below it; low and high end bracket the measured number.
By their numbers in this assay, from the lowest: compounds 1 and 2 (each within the scatter of the next); then compound 4; then compound 3.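

In this assay, hydrogen in place of methoxy on the aromatic carbon of the fused system gives a 3.5-fold lower number from compound 3 to compound 4 (0.54 log units; beyond the scatter) whereas the same exchange in compound 1 gives a 2.6-fold higher number from compound 1 to compound 4 (0.41 log units; beyond the scatter) so the direction of this exchange depends on where the methoxy sits. Cyano in place of acetyl gives a 2.1-fold higher number from compound 2 to compound 4 (0.33 log units; beyond the scatter) and thus favours acetyl at that chain carbon in this pair. No data on the cause of these shifts are available.

On these data alone, whether a hydroxyl or an amine on the fused-system carbon would track methoxy or hydrogen stays open. So does whether the acetyl preference persists with methoxy present.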